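Adding a second chlorine to the compound with the lowest number of three

The source may hold more compounds than are shown below. What is called first, only, known or untested is meant among the compounds shown, and "the series" means these compounds.

Of the compounds shown here, three have been tested in a functional assay on the whole organism (strain Wister albino) for inhibition, with Rattus norvegicus as the target, read by paw edema, with stated times of 1 h and 2 h, at a dose of 50 mg/kg by the intraperitoneal route; on this read-out higher numbers stand for more inhibition at the one dose given (going by the name of the read-out) and lower numbers for less inhibition. Compound 1 `CCOC(=O)c1c(-c2ccc(Cl)c(Cl)c2)cc(-c2ccccc2)nc1N1CCCCC1` gives 67.9%, and compound 2 `CCOC(=O)c1c(-c2ccc(Cl)cc2)cc(-c2ccccc2)nc1Nc1ccccc1` gives 73.9%; these two differ in more than one place, so their values stand side by side without a step between them. Compound 3 `CCOC(=O)c1c(-c2ccc(Cl)cc2)cc(-c2ccccc2)nc1Nc1ccc(C)cc1` gives 32.6%, the lowest of the three, and its nearest neighbour is compound 1. Among the compounds with values here, the only single-point step measured so far is a number 41.3 percentage points lower from compound 2 to compound 3 (beyond the scatter), a change that has nothing to do with chlorine.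

Compound 4 `CCOC(=O)c1c(-c2ccc(Cl)c(Cl)c2)cc(-c2ccccc2)nc1Nc1ccc(C)cc1` differs from compound 3 by chloro in place of hydrogen on an aromatic carbon. Within the data shown here, no measured step covers a chloro group entering in this way, so nothing here tells how large the step should be or which way it points. In this assay the expected step is therefore a number 7.4 percentage points higher from compound 3 to compound 4 (within the scatter), within the scatter. Compound 4 is expected to give 40%, estimated between 22% and 62%.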

Compound 4, a percentage reported as inhibition, in the whole organism at one dose (the size of the read-out at that dose, not a potency): 62.1%
The estimate for compound 4 lay 22.1 percentage points below the measured number, and the stated range ends below it.
By their numbers in this assay, from the lowest: compound 3; then compounds 4, 1 and 2 (each within the scatter of the next, the first and the last beyond it).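

In this assay, within the data shown here, chloro in place of hydrogen on this aromatic carbon, which turns 4-chlorophenyl into 3,4-dichlorophenyl, gives a number 29.5 percentage points higher from compound 3 to compound 4 (beyond the scatter) and is the first sign that this position affects the read-out. With the 3,4-dichlorophenyl group held constant, a number 5.8 percentage points lower from compound 1 to compound 4 (within the scatter) shows that (4-methylphenyl)amino and piperidin-1-yl cannot be told apart in this pair. Nothing measured here explains either step.

On these data alone, whether the chloro step would hold with piperidin-1-yl or phenylamino in place of the (4-methylphenyl)amino group remains open. So does the outcome of placing another group on this same aromatic carbon, such as fluoro, methoxy or a carboxylic acid.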